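The source may report more compounds than this note shows. Statements on the series, on what has been measured and on what is new or still open speak of the compounds shown alone.

Of the compounds shown here, three built on the shared core have been tested in a physicochemical assay for solubility, read by nephelometry, in phosphate buffer, measured as kinetic solubility, at pH 6.5 (a higher number here means a more soluble compound, a lower number a less soluble compound), and a fourth awaits measurement. Compound 1, `O=C(Nc1ccc(F)c(C(F)(F)F)c1)Nc1ccccn1`, carries a pyridin-2-yl group on the amide-type nitrogen. In this assay compound 1 gives < 1.6 ug/mL, which is a limit of the assay and not a number. Of the three values in hand, one sits at the limit of < 1.6 ug/mL in this assay, at which 1 of the 3 values shown sits, and it is this one. Compound 2, `O=C(Nc1cccc(C(=O)O)c1)Nc1ccc(F)c(C(F)(F)F)c1`, reaches 12.5 ug/mL in this assay. Compound 3, `NC(=O)c1ccccc1NC(=O)Nc1ccc(F)c(C(F)(F)F)c1`, gives 1.6 ug/mL in this assay. For the measured compounds named here, compound 1 therefore stands at the bottom of what the three values show, though only as a limit, and no step between measured pairs is available to size any change.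

The unmeasured compound 4, `O=C(Nc1cccnc1)Nc1ccc(F)c(C(F)(F)F)c1`, differs from compound 1 by a single change: pyridin-3-yl in place of pyridin-2-yl on an amide-type nitrogen. The two compounds hold the same atoms, joined differently. Going by the values given here, with no measured step to lean on, the expected step from compound 1 to compound 4 in this assay is a modest rise, an at least 1.8-fold higher number from compound 1 to compound 4 (0.27 log units; that floor lies within the scatter), close to the edge of the usual scatter. Compound 4 is expected to give roughly 3 ug/mL in this assay, with a likely range from 1 ug/mL to 10 ug/mL, and a real chance that the assay again reports only a limit.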

Compound 4, solubility: 12.5 ug/mL
Compound 4: middle estimate off by 4.2-fold (0.62 log units), on the low side; measured number above the stated range.
By their numbers in this assay, from the lowest: compound 3; then compounds 2 and 4 (each within the scatter of the next).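

Pyridin-3-yl in place of pyridin-2-yl on an amide-type nitrogen is the first change in this set whose size can be read, and in this assay it gives an at least 7.8-fold higher number from compound 1 to compound 4 (0.89 log units; beyond the scatter). For the compounds shown here, the two groups match in every count of atoms, rings, donors and acceptors, so this step goes with a difference only in how the same atoms are joined, and the earlier compounds, which offered no pair differing in one place, could not show that. The size printed for the step is a floor and not a full measure, since the value for compound 1 at its lower end is a limit of the assay and not a number: the limit of < 1.6 ug/mL in this assay, at which 1 of the 4 values shown sits.

As far as these compounds go, what pyridin-4-yl or a plain phenyl group would give on the same nitrogen stays open, as does whether a methyl group or an amine on the pyridin-3-yl ring would keep the higher number. Going by these compounds alone, also open are the true size of this step and whether the same swap would give a similar rise on a core other than the shared one, as this single pair is the only step in hand.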